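Adding a second acetyl group to a potent macrolide

A few compounds are considered here, and "the series" means these few. Any claim that something is new, unique, unknown or untested is made for them only; others in the source may bear on it.

Measured compounds:
- compound 1, `C=C/C=C\C(C)C(OC(N)=O)[C@@H](C)[C@H](O)C(C)C/C(C)=C\C(C)[C@@H](O)[C@@H](C)/C=C\C(O)C[C@@H]1OC(=O)[C@H](C)[C@@H](OC(C)=O)[C@H]1C`: 3.8 nM
- compound 2, `C=C/C=C\C(C)C(OC(N)=O)[C@@H](C)[C@H](O)C(C)C/C(C)=C\C(C)[C@@H](O)[C@@H](C)/C=C\C(C[C@@H]1OC(=O)[C@H](C)[C@@H](O)[C@H]1C)OC(C)=O`: 0.8 nM

In a functional assay on A549 cells (Homo sapiens) for inhibition (a higher number here means a weaker inhibitor, a lower number a stronger inhibitor), compound 2 gives the lower of the two numbers; compound 1 gives a number that is higher by more than the usual scatter, so compound 2 is the stronger inhibitor of the pair. Compound 3, `C=C/C=C\C(C)C(OC(N)=O)[C@@H](C)[C@H](O)C(C)C/C(C)=C\C(C)[C@@H](O)[C@@H](C)/C=C\C(C[C@@H]1OC(=O)[C@H](C)[C@@H](OC(C)=O)[C@H]1C)OC(C)=O`, has not yet been measured. It differs from compound 2 in one place: acetyl in place of hydrogen on an oxygen on a saturated carbon. The two acetyl groups of compound 1 and compound 2 sit at different places, so the pair alone does not tell what a second acetyl group will do. Compound 3 is therefore expected to stay close to compound 2, and the step of a 1.9-fold higher number from compound 2 to compound 3 (0.27 log units; within the scatter) is estimated to lie within or only slightly beyond the scatter. For compound 3 a value of about 1.5 nM is expected, within a range from 0.4 nM to 6 nM.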

Compound 3, half-maximal inhibitory concentration: 0.8 nM
Compound 3: middle estimate off by 1.9-fold (0.27 log units), on the high side; the measured number falls inside the stated range.
By their numbers in this assay, from the lowest: compounds 2 and 3 (each within the scatter of the next); then compound 1.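

In this assay, putting acetyl in place of hydrogen on the oxygen on a saturated carbon whose other neighbours are saturated ring carbon gives no change at the digits printed from compound 2 to compound 3 (within the scatter), so an acetoxy group at this place, alongside the second acetoxy group, costs nothing measurable compared with the hydroxy group. The same kind of swap at the other oxygen gives a 4.8-fold lower number from compound 1 to compound 3 (0.68 log units; beyond the scatter), so hydroxy to acetoxy does not read the same at the two places, and only this second place moves the number beyond the scatter. No measurement here explains this difference between the two places.

Still open, from the compounds shown here alone, is whether this tolerance extends beyond acetyl, for example to a longer acyl chain such as butanoyl or to an amine at the same oxygen. The compounds shown also cannot say how a compound with a hydroxy group at both places would compare.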